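Replacing 3,5-dimethoxyphenyl with 4-fluorophenyl in compound 2

A few compounds are considered here, and "the series" means these few. Any claim that something is new, unique, unknown or untested is made for them only; others in the source may bear on it.

Compound 1 `O=S(=O)(c1ccc(Br)cc1)c1nc2ccccc2nc1Nc1ccccc1` gives 130 nM
Compound 2 `COc1cc(Nc2nc3ccccc3nc2S(=O)(=O)c2ccc(Br)cc2)cc(OC)c1` gives 2540 nM
Compound 3 `COc1cc(Nc2nc3ccccc3nc2S(=O)(=O)c2ccc(Br)cc2)cc(OC)c1OC` gives 1020 nM

All three compounds were tested in a functional assay on HL-60 cells (Homo sapiens) for cytotoxicity, read by MTT assay, with a stated time of 72 h (on this read-out higher numbers stand for weaker inhibition and lower numbers for stronger inhibition), and differ in the group on the nitrogen. Compound 2 has the highest number of the three and so shows the weakest inhibition among them. Compound 3 is its nearest neighbour, and compound 1 lies furthest from it.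

The change followed here leads to compound 4 `O=S(=O)(c1ccc(Br)cc1)c1nc2ccccc2nc1Nc1ccc(F)cc1` and has not yet been measured. In it, 4-fluorophenyl stands in place of 3,5-dimethoxyphenyl on a nitrogen on an aromatic ring, which amounts to 4-fluorophenyl in place of 3,5-dimethoxyphenyl on a nitrogen on an aromatic ring in the counted difference.

Among the compounds with values here, two measured steps bear on this. The closer one is a 20-fold higher number from compound 1 to compound 2 (1.29 log units; beyond the scatter) when 3,5-dimethoxyphenyl replaces phenyl, a large step. The other is a 2.5-fold lower number from compound 2 to compound 3 (0.40 log units; beyond the scatter) when methoxy replaces hydrogen on an aromatic carbon, a modest step. Compound 4 has no methoxy groups, as compound 1 has none, so most of the large step is expected to be undone. Within the data shown here, no measured compound carries 4-fluorophenyl, which leaves the range wide.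

In this assay the expected step is a 12-fold lower number from compound 2 to compound 4 (1.06 log units; beyond the scatter) by this estimate. Compound 4 is expected at 220 nM with an estimated range of 70 nM to 700 nM on this reasoning.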

Compound 4, half-maximal inhibitory concentration: 260 nM
Estimate against measurement, compound 4: 1.2-fold (0.07 log units) below; the measured number falls inside the stated range.
By their numbers in this assay, from the lowest: compounds 1 and 4 (each within the scatter of the next); then compound 3; then compound 2.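

In this assay the exchange of 3,5-dimethoxyphenyl for 4-fluorophenyl on the nitrogen gives a 9.8-fold lower number from compound 2 to compound 4 (0.99 log units; beyond the scatter), which shows that a phenyl ring carrying a substituent at this place does not in itself bring the high number seen with the methoxy-bearing compound 2 and compound 3. The unsubstituted phenyl and the 4-fluorophenyl cannot be told apart here, since the fluoro for hydrogen exchange gives a 2.0-fold higher number from compound 1 to compound 4 (0.30 log units; within the scatter), so this position accepts that change without a step that can be read. No measurement shown here explains why the 3,5-dimethoxyphenyl group stands so far from the other two.

The compounds shown leave open whether a single methoxy, as in 4-methoxyphenyl, would fall with the 3,5-dimethoxyphenyl compounds or with compound 1 and compound 4, and where a 4-aminophenyl or a 4-carboxyphenyl group on this nitrogen would fall. They also leave open whether a chlorine in place of the fluorine would likewise stay within the scatter of compound 1.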